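A Trifluoromethyl in Place of Fluoro on Compound 2

The source may report more compounds than this note shows. Statements on the series, on what has been measured and on what is new or still open speak of the compounds shown alone.

Going by the values given here, in an ADME assay on Vero cells (Chlorocebus sabaeus) for cytotoxicity, read by resazurin assay, with a stated time of 72 h (on this read-out higher numbers stand for weaker inhibition and lower numbers for stronger inhibition), only two compounds have numbers so far. Compound 1 (`COc1ccc(C(=O)CCN2CCN(c3ccc(C(F)(F)F)cc3)CC2)cc1`) gives 135000 nM and compound 2 (`O=C(CCN1CCN(c2ccc(F)cc2)CC1)c1ccc(F)c(F)c1`) gives 385000 nM on this read-out. Compound 2 thus holds the higher number of the two, with a gap beyond the scatter, although the pair differs in more than one place. Compound 3 (`O=C(CCN1CCN(c2ccc(C(F)(F)F)cc2)CC1)c1ccc(F)c(F)c1`) is compound 2 with trifluoromethyl in place of fluoro on an aromatic carbon, para to a large group (trifluoromethyl in place of fluoro on an aromatic carbon). Among the compounds with values here, no measured pair shows this change alone. Compound 1 also carries trifluoromethyl and reads 135000 nM in this assay as well, so a step toward a lower number, modestly beyond the scatter, is expected. The expected change is a 2.3-fold lower number from compound 2 to compound 3 (0.36 log units; beyond the scatter) on this estimate. Compound 3 is expected near 170000 nM with a range from 80000 nM to 350000 nM as the likely span.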

Compound 3, half-maximal inhibitory concentration: 14000 nM
Compound 3: middle estimate off by 12-fold (1.08 log units), on the high side; measured number outside the range, below it.
By their numbers in this assay, from the lowest: compound 3; then compound 1; then compound 2.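

In this assay, trifluoromethyl in place of fluoro on an aromatic carbon, para to a large group, gives a 28-fold lower number from compound 2 to compound 3 (1.44 log units; beyond the scatter), which shows that this single change moves the number a long way, something the earlier pair, differing in more than one place, could not show. With trifluoromethyl held fixed, 3,4-difluorophenyl in place of 4-methoxyphenyl on a carbonyl carbon gives a 9.6-fold lower number from compound 1 to compound 3 (0.98 log units; beyond the scatter), so the group on the carbonyl carbon also shifts the number, though by less. Nothing measured here speaks to the reason for either step.

On these data alone, whether a chloro group or a nitrile at the same aromatic carbon would read nearer to fluoro or to trifluoromethyl stays open. Also open, as far as these compounds go, is whether the trifluoromethyl step would be as large with 4-methoxyphenyl on the carbonyl carbon.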